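Changing the aryl group on the amine of a shared core

A few compounds are considered here, and "the series" means these few. Any claim that something is new, unique, unknown or untested is made for them only; others in the source may bear on it.

Measured compounds:
Compound 1, `C=CC(=O)Nc1cccc(NC(=O)CSc2nc(Nc3cccc([N+](=O)[O-])c3)c3ccccc3n2)c1`, in a functional assay on MGC-803 cells (Homo sapiens) for inhibition, read by MTT assay, with a stated time of 72 h (a lower number here means a stronger inhibitor, a higher number a weaker inhibitor), gives > 50000 nM, which is a limit of the assay rather than a number.
Compound 2, `C=CC(=O)Nc1cccc(NC(=O)CSc2nc(Nc3cccc(OC)c3)c3ccccc3n2)c1`, in this assay gives 24200 nM.

For the measured compounds named here, compound 2 therefore holds the only number in this assay; the other value is a limit (the limit of > 50000 nM in this assay, at which 1 of the 2 values shown sits). Going by the values given here, the single measured step is an at least 2.0-fold lower number from compound 1 to compound 2 (0.31 log units; beyond the scatter), at least modest and beyond the scatter, reached by a methoxy in place of a nitro group on the aryl ring attached to the amine of the core.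

Compound 3, `C=CC(=O)Nc1cccc(NC(=O)CSc2nc(Nc3ccc(Cl)cc3)c3ccccc3n2)c1`, differs from compound 2 by 4-chlorophenyl in place of 3-methoxyphenyl on a nitrogen on an aromatic ring. Among the compounds with values here, the measured step bears on it only loosely: it also alters the substituent on this aryl ring, but the present change moves from methoxy to chloro at a different position, so no direct precedent exists. A step within the scatter, or at most modest in either direction, is expected from compound 2 to compound 3, a 1.3-fold lower number from compound 2 to compound 3 (0.13 log units; within the scatter). Compound 3 is accordingly estimated at 18000 nM in this assay, within a range from 5000 nM to 50000 nM.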

Compound 3, half-maximal inhibitory concentration: 14300 nM
Estimate against measurement, compound 3: 1.3-fold (0.10 log units) above; measured number inside the range.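

In this assay, 4-chlorophenyl and 3-methoxyphenyl on the nitrogen of the shared core cannot be told apart: the result is a 1.7-fold lower number from compound 2 to compound 3 (0.23 log units; within the scatter). The earlier compounds shown here showed only that 3-methoxyphenyl differs from 3-nitrophenyl, but a second group, with chlorine in place of the methoxy oxygen and carbon, now also gives a clear separation from 3-nitrophenyl, namely an at least 3.4-fold lower number from compound 1 to compound 3 (0.54 log units; beyond the scatter). So far, then, compound 1 is the one that stands apart among these three, and its figure is a limit of the assay and not a number: the limit of > 50000 nM in this assay, at which 1 of the 3 values shown sits.

The step to compound 3 changes both the substituent and its place on the ring, so the effect of either one alone cannot be read from these compounds, and a single comparison of this kind says little about how the position behaves in general. Also open, as far as these compounds go, is how a plain phenyl, a 3-chlorophenyl, a phenyl ring carrying an amine or a carboxylic acid, or a benzyl group on this nitrogen would read in this assay.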